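Methoxy to Bromo on a Thiazoloimidazole Scaffold, Second Instance

The source may hold more compounds than are shown below. What is called first, only, known or untested is meant among the compounds shown, and "the series" means these compounds.

The measured compounds:
compound 1, `CCOC(=O)c1csc2nc(CN3CCN(Cc4ccccc4)CC3)c(-c3ccc(OC)cc3)n12`, 9940 nM;
compound 2, `CCOC(=O)c1csc2nc(CN3CCN(Cc4ccccc4)CC3)c(-c3ccc(Br)cc3)n12`, 29500 nM;
compound 3, `COc1ccc(-c2c(CN3CCCCC3)nc3scc(C(=O)O)n23)cc1`, 47400 nM.

All three were tested in a functional assay on HeLa cells (Homo sapiens) for antiproliferative activity, read by MTT assay, with a stated time of 72 h; on this read-out higher numbers stand for weaker inhibition and lower numbers for stronger inhibition. Compound 1 and compound 2 share a core and differ only by bromo in place of methoxy on an aromatic carbon; that change gave a 3.0-fold higher number from compound 1 to compound 2 (0.47 log units; beyond the scatter). Compound 3 carries a different core, and the difference between the two cores is not broken down here. Compound 4, `O=C(O)c1csc2nc(CN3CCCCC3)c(-c3ccc(Br)cc3)n12`, is not yet measured; it differs from compound 3 by bromo in place of methoxy on an aromatic carbon, the same change seen from compound 1 to compound 2.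

Since the earlier instance of this change produced a 3.0-fold higher number from compound 1 to compound 2 (0.47 log units; beyond the scatter), a step of similar size is expected in this assay, giving a 2.7-fold higher number from compound 3 to compound 4 (0.44 log units; beyond the scatter). Compound 4 is therefore estimated at 130000 nM, with a likely range from 45000 nM to 350000 nM.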

Compound 4, half-maximal inhibitory concentration: 76600 nM
Compound 4: the middle estimate sits 1.7-fold (0.23 log units) above what was measured, within the range that was stated.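

In this assay, bromo in place of methoxy on the core of compound 3 gave a 1.6-fold higher number from compound 3 to compound 4 (0.21 log units; within the scatter), so on this core the step does not stand clear of the scatter. Set beside the earlier step, the change does not differ measurably between the two cores: the same change on two cores in this assay, a 3.0-fold higher number (0.47 log units; beyond the scatter) from compound 1 to compound 2 and a 1.6-fold higher number (0.21 log units; within the scatter) from compound 3 to compound 4, 1.8-fold (0.26 log units) apart, within the scatter of two such steps

Within the data shown here, this agreement rests on only two pairs, so it does not show that the step keeps a fixed size on other cores, and it gives no reason for the size of either step. The compounds shown leave open how other groups at the same place, such as fluoro, an amine or a nitrile, would compare with methoxy and bromo. On these data alone, it also remains open how the ethyl ester and the carboxylic acid compare when nothing else in the compound differs.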